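Triazolyl methyl ester series: cytotoxicity notes

This account rests on a few compounds, and the source may have more. Where it says the series, first, only, none or still open, it means among the compounds named here.

Measured compounds:
Compound 1 `Cc1ccc(-n2cc(COC(=O)c3c(C)nc4ccccc4c3-c3ccccc3)nn2)cc1` — 39000 nM
Compound 2 `Cc1ccc(-n2cc(COC(=O)c3c(C)nc4ccc(Cl)cc4c3-c3ccccc3)nn2)cc1` — "not determined" (no result reported)

Within the data shown here, compound 1 is the only member with a number in an ADME assay on J774.A1 cells (Mus musculus) for cytotoxicity, read by MTT assay, with a stated time of 48 h; on this read-out lower numbers stand for higher toxicity in this test and higher numbers for lower toxicity in this test: compound 1 gives 39000 nM. Going by these compounds, compound 2 carries a chlorine on the shared core that compound 1 lacks, but compound 2 gives "not determined" (no result reported) in this assay, so nothing can be said about where compound 2 stands relative to compound 1 beyond the fact that the gap is unknown.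

Compound 3 `Cc1nc2ccc(Cl)cc2c(-c2ccccc2)c1C(=O)OCc1cn(Cc2ccccc2)nn1` is the next compound. It has the same atoms as compound 2, joined differently: benzyl in place of 4-methylphenyl on an aromatic nitrogen. Among the measured compounds shown here, no measured pair shows what this kind of change does in this assay, so no step size can be read from the data; given the shared chlorinated core and the small, isomeric nature of the change, the expectation is a step of no more than the usual scatter in either direction. Resting on the one number available, that of compound 1 at 39000 nM, compound 3 is estimated at 35000 nM, with an expected range from 10000 nM to 100000 nM.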

Compound 3, half-maximal cytotoxic concentration: 35000 nM
Beside the measured number, compound 3's estimate shows no gap at the digits printed, within the range that was stated.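

No new step can be read from compound 3: compound 2, which differs from it in one place, has no single number, and compound 1 differs from it in more than one place. Nothing shown bears on the cause of the result. Still open, going by these compounds, is what the change from 4-methylphenyl to benzyl, or the chlorine alone, does in this assay.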